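Removing a tert-Butoxycarbonyl Group on Two Related Anilides

The compounds below may be only part of what the source reports. "The series", "measured", "known", "first", "only" and "open" are said of these compounds alone.

Compound 1 `CSCC[C@H](NC(=O)c1cc(Cl)ccc1OCCNC(=O)OC(C)(C)C)C(=O)Nc1ccc([N+](=O)[O-])cc1Cl`: > 10000 nM
Compound 2 `CSCC[C@H](NC(=O)c1cc(Cl)ccc1OCCN)C(=O)Nc1ccc([N+](=O)[O-])cc1Cl`: > 10000 nM
Compound 3 `CC(C)(C)OC[C@@H](NC(=O)c1cc(Cl)ccc1OCCNC(=O)OC(C)(C)C)C(=O)Nc1ccc([N+](=O)[O-])cc1Cl`: > 10000 nM

In a functional assay on MDA-MB-231 cells (Homo sapiens) for inhibition, read by MTT assay, with a stated time of 72 h (on this read-out lower numbers stand for stronger inhibition and higher numbers for weaker inhibition), compound 1 gives > 10000 nM, which is a limit of the assay rather than a number. Compound 2 likewise gives > 10000 nM, also a limit. Compound 3 gives > 10000 nM, again only a limit. The change from compound 1 to compound 2 is hydrogen in place of tert-butoxycarbonyl on an amine nitrogen; the step that the two limits leave unreadable from compound 1 to compound 2 cannot be read because the limit of > 10000 nM in this assay, at which 3 of the 3 values shown sit, covers both ends. The difference between the cores of compound 1 and compound 3 is not broken down here. Compound 4 `CC(C)(C)OC[C@@H](NC(=O)c1cc(Cl)ccc1OCCN)C(=O)Nc1ccc([N+](=O)[O-])cc1Cl` arises from compound 3 by the same change, (hydrogen in place of tert-butoxycarbonyl on an amine nitrogen), at the same place. From compound 3 the expected step is a step that the limit leaves unreadable from compound 3 to compound 4, an estimate resting on compound 3 sitting at a limit and on the unreadable step that the two limits leave unreadable from compound 1 to compound 2. Compound 4 is therefore expected to fall near 20000 nM, between 8000 nM and 100000 nM, most likely again as a limit.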

Compound 4, half-maximal inhibitory concentration: 3220 nM
Compound 4: middle estimate off by 6.2-fold (0.79 log units), on the high side; measured number below the stated range.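

On the core of compound 3, hydrogen in place of tert-butoxycarbonyl on an amine nitrogen gives an at least 3.1-fold lower number from compound 3 to compound 4 (0.49 log units; beyond the scatter), and in this assay compound 4 reaches 3220 nM. On the core of compound 1 the same change cannot be read, because both ends of that step sit at a limit: the limit of > 10000 nM in this assay, at which 3 of the 4 values shown sit. Compound 2 thus remains at a limit, so these compounds neither confirm nor rule out that the change carries from one core to the other, and the step on the core of compound 3 gives only a minimum size.

The compounds shown leave open whether a longer chain ending in an amine would match compound 4. They also leave open how a carboxylic acid in place of that amine would behave on either core.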